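A few compounds are considered here, and "the series" means these few. Any claim that something is new, unique, unknown or untested is made for them only; others in the source may bear on it.

Measured so far in a functional assay on HeLa cells (Homo sapiens) for antiproliferative activity, read by MTT assay, with a stated time of 48 h; a lower number here means a stronger inhibitor, a higher number a weaker inhibitor:

Compound 1, `Fc1ccc2[nH]c(-c3cn(-c4ccccc4)nc3-c3ccccc3)nc2c1`, gives 3610 nM.
Compound 2, `Clc1ccc2[nH]c(-c3cn(-c4ccccc4)nc3-c3ccccc3)nc2c1`, gives 3480 nM.
Compound 3, `Fc1ccc2[nH]c(-c3cn(-c4ccccc4)nc3-c3ccc(Cl)cc3)nc2c1`, gives 2770 nM.

The three numbers sit close together. From compound 1 to compound 2 the change is chloro in place of fluoro on an aromatic carbon, and in this assay it gives a 1.0-fold lower number from compound 1 to compound 2 (0.02 log units; within the scatter). From compound 1 to compound 3 the change is chloro in place of hydrogen on an aromatic carbon, with a 1.3-fold lower number from compound 1 to compound 3 (0.12 log units; within the scatter). Compound 3 has the lowest of the three numbers, but its gaps to compound 2 and to compound 1 are both within the scatter, so no order among the three is claimed.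

Compound 4, `Clc1ccc(-c2nn(-c3ccccc3)cc2-c2nc3cc(Cl)ccc3[nH]2)cc1`, is not yet measured. It differs from compound 3 by chloro in place of fluoro on an aromatic carbon. This is the same change as that from compound 1 to compound 2, at a place described in the same words, so it is counted twice in the set. The core of compound 3 differs from the core of compound 1 by chloro in place of hydrogen on an aromatic carbon, and there is no evidence that this core difference alters how the chloro-for-fluoro exchange plays out.

For compound 4 in this assay the step is expected to be a 1.0-fold lower number from compound 3 to compound 4 (0.01 log units; within the scatter), essentially flat, because the same exchange from compound 1 to compound 2 gave a 1.0-fold lower number from compound 1 to compound 2 (0.02 log units; within the scatter). The estimate for compound 4 is therefore 2700 nM, with a range from 1400 nM to 5200 nM that reflects the usual scatter of this kind of measurement rather than any expected shift.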

Compound 4, half-maximal inhibitory concentration: 1630 nM
Compound 4: middle estimate off by 1.7-fold (0.22 log units), on the high side; the measured number falls inside the stated range.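

In this assay the exchange of chloro for fluoro gives a 1.7-fold lower number from compound 3 to compound 4 (0.23 log units; within the scatter), and its two occurrences do not differ beyond the scatter: the same change on two cores in this assay, a 1.0-fold lower number (0.02 log units; within the scatter) from compound 1 to compound 2 and a 1.7-fold lower number (0.23 log units; within the scatter) from compound 3 to compound 4, 1.6-fold (0.21 log units) apart, within the scatter of two such steps. Among the compounds shown here, the exchange of chloro for hydrogen gives a 2.1-fold lower number from compound 2 to compound 4 (0.33 log units; beyond the scatter), the only one of these steps printed as beyond the scatter, and it too stays in line with its earlier counterpart: the same change on two cores in this assay, a 1.3-fold lower number (0.12 log units; within the scatter) from compound 1 to compound 3 and a 2.1-fold lower number (0.33 log units; beyond the scatter) from compound 2 to compound 4, 1.6-fold (0.21 log units) apart, within the scatter of two such steps. Each change therefore carries from one core to another in these four compounds with no detectable difference, but this rests on a single pair of steps per change; it does not show that either change would transfer the same way to any other core, and the modest size of the steps leaves little room to detect a real dependence on the core.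

The compounds shown hold only hydrogen, fluoro or chloro at the two varied places, so it remains open how an amine, a carboxylic acid, a methoxy group or a longer chain would behave there. As far as these compounds go, it also remains open whether the same steps would hold on other cell lines or in any read-out other than this assay.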